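The compounds below may be only part of what the source reports. "The series", "measured", "known", "first", "only" and "open" are said of these compounds alone.

Notes on the series, read in an ADME assay on CEM-SS cells (Homo sapiens) for cytotoxicity, read by XTT assay, with a stated time of 6 days (a higher number here means that more compound is tolerated, a lower number that less compound is tolerated), throughout. Compound 1 (`CCCC(=O)OCSc1ccccc1C(=O)NCCC(N)=O`) gives > 100 uM as a limit of the assay and not a number. Compound 2 (`CCCC(=O)OCSc1ccccc1C(=O)NCC(=O)N(C)C`) gives 38.3 uM and compound 3 (`C#CCNC(=O)CNC(=O)c1ccccc1SCOC(=O)CCC`) gives 95.4 uM as the higher of the two actual numbers. Compound 4 (`CCCC(=O)OCSc1ccccc1C(=O)NCC(=O)NCC(N)=O`) differs from compound 3 by one change (carbamoyl in place of ethynyl on a saturated chain carbon bound to an amide-type nitrogen): carbamoyl in place of ethynyl on a saturated chain carbon bound to an amide-type nitrogen. Compound 1 also carries carbamoylmethyl, and its step stays within the scatter at its floor (an at least 1.0-fold lower number from compound 1 to compound 3 (0.02 log units; that floor lies within the scatter)), while compound 2 sits lower (a 2.5-fold higher number from compound 2 to compound 3 (0.40 log units; beyond the scatter)). No step beyond the scatter is therefore expected in this assay for this change. The expected step is small (a 1.2-fold higher number from compound 3 to compound 4 (0.06 log units; within the scatter)). The estimate for compound 4 is 110 uM (expected range 55 uM to 200 uM).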

Compound 4, half-maximal toxic concentration: > 100 uM
Compound 4 gave a limit, no number (the forecaster's own chance of this, stated with the estimate: 60%); the middle value lies beyond the limit too.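

In this assay carbamoyl in place of ethynyl on a saturated chain carbon bound to an amide-type nitrogen gives only a floor, an at least 1.0-fold higher number from compound 3 to compound 4 (0.02 log units; that floor lies within the scatter), so the size of this change cannot be read. (Carbamoylmethyl)amino in place of dimethylamino on a carbonyl carbon gives an at least 2.6-fold higher number from compound 2 to compound 4 (0.41 log units; beyond the scatter), so compound 4 joins compound 3 in standing apart from compound 2. The step from compound 1 to compound 4 cannot be read, and the series now meets the limit of the read-out: the limit of > 100 uM in this assay, at which 2 of the 4 values shown sit.

Going by these compounds, whether a carboxylic acid or an amine on this chain carbon, or a longer chain, would give a number rather than a limit remains open.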